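Trifluoromethyl to fluoro: a single-group change in the series

The source may report more compounds than this note shows. Statements on the series, on what has been measured and on what is new or still open speak of the compounds shown alone.

In a functional assay on MIA PaCa-2 cells (Homo sapiens) for cytotoxicity, read by MTT assay, with a stated time of 72 h (on this read-out lower numbers stand for stronger inhibition and higher numbers for weaker inhibition), compound 1 (`COC1=CC(=O)c2c(COc3ccc(C#N)cc3)c(C)n(C)c2C1=O`) gives 192 nM and compound 2 (`COC1=CC(=O)c2c(COc3ccc(C(F)(F)F)cc3)c(C)n(C)c2C1=O`) gives 311 nM. These two values lie within the scatter of each other, so compound 2 has a single neighbour on the numbers and no clear rank against it.

Compound 3 (`COC1=CC(=O)c2c(COc3ccc(F)cc3)c(C)n(C)c2C1=O`) is not yet measured. It keeps the shared core and differs from compound 2 in one group: fluoro in place of trifluoromethyl on an aromatic carbon. In words, this is fluoro in place of trifluoromethyl on an aromatic carbon, para to a large group.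

Within the data shown here, only one measured step bears on this change, a swap at the same place: a 1.6-fold higher number from compound 1 to compound 2 (0.21 log units; within the scatter). Among the measured compounds shown here, no fluoro compound has been measured yet, so this single step is thin evidence. With that limitation, no step beyond the scatter is expected in this assay, and no direction is favoured. The estimate amounts to a 1.2-fold lower number from compound 2 to compound 3 (0.09 log units; within the scatter), an expected step within the scatter. For compound 3 the estimated value is 250 nM, with an expected range of 110 nM to 560 nM.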

Compound 3, half-maximal inhibitory concentration: 493 nM
Compound 3: the middle estimate sits 2.0-fold (0.29 log units) below what was measured; measured number inside the range.
By their numbers in this assay, from the lowest: compounds 1, 2 and 3 (each within the scatter of the next, the first and the last beyond it).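

Among these compounds, at this position, on an aromatic carbon para to a large group, a swap now gives a step beyond the scatter in this assay for the first time, though a modest one (a 2.6-fold higher number from compound 1 to compound 3 (0.41 log units; beyond the scatter)), with fluoro in place of cyano. Fluoro in place of trifluoromethyl stays within the scatter (a 1.6-fold higher number from compound 2 to compound 3 (0.20 log units; within the scatter)), so compound 2 cannot be ordered against compound 1 or compound 3, and the three groups separate only at the two ends of the series. No measurement shown bears on what lies behind the step from cyano to fluoro, which stays unexplained.

Open at this position is whether a methoxy, an amine or a carboxylic acid would fall inside the same span of values or outside it, as three groups give too little to define a trend. Also open, as far as these compounds go, is whether the step between cyano and fluoro would persist with a change elsewhere on the shared core or in the ether link, both of which stay constant across these compounds.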